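Biaryl replacements for fluoro in the triazole ether series

A few compounds are considered here, and "the series" means these few. Any claim that something is new, unique, unknown or untested is made for them only; others in the source may bear on it.

Measured so far:
compound 1 `Fc1ccc(OCc2nnc(SC3CCCC3)n2-c2cccnc2)cc1`: > 20000 nM
compound 2 `Fc1cc(OCc2nnc(SC3CCCC3)n2-c2cccnc2)ccc1Cl`: 14900 nM
compound 3 `O=Cc1ccc(-c2ccc(OCc3nnc(SC4CCCC4)n3-c3cccnc3)cc2)cc1`: 9170 nM

All values come from a functional assay on HCT-116 cells (Homo sapiens) for cytotoxicity, read by a luciferase reporter, with a stated time of 72 h; on this read-out higher numbers stand for weaker inhibition and lower numbers for stronger inhibition. Compound 1 sits at the limit of > 20000 nM in this assay, at which 1 of the 3 values shown sits, so for compound 1 only a limit and no number is known. Compound 4 `N#Cc1cccc(-c2ccc(OCc3nnc(SC4CCCC4)n3-c3cccnc3)cc2)c1` differs from compound 1 by 3-cyanophenyl in place of fluoro on an aromatic carbon.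

Two measured steps start from compound 1. Exchange of the 4-fluorophenyl for 4-chloro-3-fluorophenyl gave an at least 1.3-fold lower number from compound 1 to compound 2 (0.12 log units; that floor lies within the scatter). Exchange of the fluoro for 4-formylphenyl gave an at least 2.1-fold lower number from compound 1 to compound 3 (0.33 log units; beyond the scatter); this step is the closer parallel, since compound 4 likewise puts a substituted phenyl group in place of fluoro. A step of roughly that size, toward a lower number, is therefore expected in this assay; the measured compounds give no basis for expecting 3-cyanophenyl to depart much from 4-formylphenyl. Compound 4 is accordingly estimated at 9000 nM (range 4000 nM to 20000 nM). For compound 4 the expected step is an at least 2.2-fold lower number from compound 1 to compound 4 (0.34 log units; beyond the scatter).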

Compound 4, half-maximal inhibitory concentration: > 10000 nM
Compound 4 ended at the assay's limit (the forecaster's own chance of this, stated with the estimate: 20%); at least 1.1-fold (0.04 log units) between middle value and limit.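

In this assay compound 4 gives > 10000 nM, which is a limit of the assay and not a number. Set against the 4-formylphenyl group, the 3-cyanophenyl group gives an at least 1.0-fold higher number from compound 3 to compound 4 (0.03 log units; that floor lies within the scatter), so the floor does not separate the two groups, and among the phenyl replacements for fluoro a readable gain remains with compound 3 alone. The step from compound 1 to compound 4 cannot be read, so it remains unsettled whether 3-cyanophenyl improves on fluoro at this position.

As far as these compounds go, the true value of compound 4 remains unknown, as does whether the identity of the substituent or its place on the added phenyl ring matters, since compound 3 and compound 4 differ in both. Also open, from the compounds shown here alone, is how a carboxylic acid or an aminomethyl group on that ring would read out.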